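A few compounds are considered here, and "the series" means these few. Any claim that something is new, unique, unknown or untested is made for them only; others in the source may bear on it.

Measured compounds:
compound 1, `CC(=O)NCCN(C)c1cccc(OCCCCCCNC(=O)Oc2cccc(-c3ccccc3)c2)c1` — 1.34 nM
compound 2, `CC(=O)NCCN(C)c1cccc(OCCCCCCOc2cccc(O)c2)c1` — "not determined" (no result reported)

Going by the values given here, compound 1 is the only compound of this set with a single number in an assay (brain, strain Wistar) for inhibition of Fatty-acid amide hydrolase 1 (Rattus norvegicus), read by scintillation counting, with a stated time of 30 min; on this read-out lower numbers stand for stronger inhibition and higher numbers for weaker inhibition; compound 2 carries no result there, so compound 1 stands alone and nothing can be said of its rank against another compound. The unmeasured compound 3, `CC(=O)NCCN(C)c1cccc(OCCCCCCNC(=O)Oc2cccc(-c3cccc(O)c3)c2)c1`, differs from compound 1 in one place: hydroxy in place of hydrogen on an aromatic carbon. Among the compounds with values here, no step between two measured compounds is available, so the size of this change can only be expected, not read off. The account expects the step of a 1.9-fold higher number from compound 1 to compound 3 (0.27 log units; within the scatter) from compound 1 to compound 3 to be small in this assay, at most a modest move toward weaker inhibition and possibly none beyond the scatter. On that basis compound 3 is estimated at 2.5 nM in this assay, with a range from 0.6 nM to 10 nM.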

Compound 3, half-maximal inhibitory concentration: 0.36 nM
For compound 3 the middle estimate is 6.9-fold (0.84 log units) above the measured one; the whole stated range lies above it.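

Going from phenyl to 3-hydroxyphenyl brings a 3.7-fold lower number from compound 1 to compound 3 (0.57 log units; beyond the scatter) in this assay, so this position is not indifferent to the change, and the added hydroxy goes with stronger inhibition rather than weaker. The step also shows that compound 1, already at 1.34 nM, still leaves room for a lower number through a single added oxygen atom on this aromatic ring. No supporting measurement bears on why the number falls, and the step itself gives no reason for it.

With one step at this position, the compounds shown leave open whether the shift belongs to the hydroxy as such or to any added group in that place. They also do not tell how a methoxy, an amine or a carboxylic acid on the same aromatic carbon would read in this assay.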